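Swapping Trifluoromethoxy for Trifluoromethyl on a Cytotoxicity Read-out

The source may hold more compounds than are shown below. What is called first, only, known or untested is meant among the compounds shown, and "the series" means these compounds.

Among the measured compounds shown here, compound 1 `CN1CCN(CCNCc2cn(-c3ccc(F)cc3F)nc2-c2ccc(OC(F)(F)F)cc2)CC1` holds the higher of the two numbers measured so far in an ADME assay on Huh-7 cells (Homo sapiens) for cytotoxicity (a lower number here means that less compound is tolerated, a higher number that more compound is tolerated), giving 18000 nM. Compound 2 `CCCN1CCC(CNCc2cn(-c3ccc(C(F)(F)F)cc3)nc2-c2ccc(C(F)(F)F)cc2)CC1`, which differs from it in several places, gives 1200 nM in this assay. Compound 3 `CN1CCN(CCNCc2cn(-c3ccc(F)cc3F)nc2-c2ccc(C(F)(F)F)cc2)CC1` has not yet been measured. It differs from compound 1 in a single place: trifluoromethyl in place of trifluoromethoxy on an aromatic carbon. For the measured compounds named here, no measured pair isolates this change, so the expectation rests on how small the difference is, a single oxygen leaving from one arm of the shared core of compound 1. For compound 3 a step of a 1.3-fold lower number from compound 1 to compound 3 (0.11 log units; within the scatter) in this assay is expected, a slight move toward a less tolerated compound that is unlikely to stand out from the usual scatter. Compound 3 is therefore estimated at 14000 nM, with a likely range from 5000 nM to 35000 nM.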

Compound 3, half-maximal cytotoxic concentration: 20000 nM
Compound 3: the middle estimate sits 1.4-fold (0.15 log units) below what was measured; low and high end bracket the measured number.
By their numbers in this assay, from the lowest: compound 2; then compounds 1 and 3 (each within the scatter of the next).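

Trifluoromethyl in place of trifluoromethoxy gives a 1.1-fold higher number from compound 1 to compound 3 (0.05 log units; within the scatter) in this assay, the first comparison here in which only one place differs. With the rest of the shared core held constant, the loss of this single oxygen from the 4-(trifluoromethoxy)phenyl arm leaves no measurable mark on this read-out, so the two groups cannot be told apart at this position. Nothing measured here accounts for this result or describes how the two groups differ in behaviour.

The compounds shown leave open whether a different group at this position, such as a nitrile, a chlorine atom or an amine, would shift the number beyond the usual scatter. They also leave open whether the same swap would give so small a step on a core other than that of compound 1.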